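This account rests on a few compounds, and the source may have more. Where it says the series, first, only, none or still open, it means among the compounds named here.

Of the compounds shown here, three that share one core have been measured in an assay on HEK293 cells for displacement of a labelled ligand from NPC1-like intracellular cholesterol transporter 1 (Homo sapiens); a lower number here means a stronger inhibitor, a higher number a weaker inhibitor. Compound 1 `O=C(CN1CN(c2ccccc2)C2(CCN(C(=O)c3ccc(C4CCCCC4)cc3)CC2)C1=O)NCCCCO` gives 10300 nM there. Compound 2 `CC(C)(C)c1ccc(C(=O)N2CCC3(CC2)C(=O)N(CC(=O)N2CCCC(C(N)=O)C2)CN3c2ccccc2)cc1` gives 16900 nM. Compound 3 `CC(C)(C)OC(=O)NC1CCN(C(=O)CN2CN(c3ccccc3)C3(CCN(C(=O)c4ccc(C5CCCCC5)cc4)CC3)C2=O)CC1` gives 4800 nM. Compound 2 stands at the highest of these three numbers, which marks it as the weakest binder among them on this read-out. Its nearest neighbour is compound 1, and the gap between those two is within the scatter of such measurements, so the two cannot be told apart. The gap to compound 3 lies beyond the scatter, so compound 3 is the stronger binder of that pair.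

Compound 4 `CC(C)(C)c1ccc(C(=O)N2CCC3(CC2)C(=O)N(CC(=O)N2CCN(S(C)(=O)=O)CC2)CN3c2ccccc2)cc1` has not yet been measured. It is built from compound 2 by one change: 4-(methylsulfonyl)piperazin-1-yl in place of 3-carbamoylpiperidin-1-yl on a carbonyl carbon. Both groups are six-membered non-aromatic rings joined to the same carbonyl carbon, whose other neighbour is a saturated chain carbon.

Among the compounds with values here, no pair of measured compounds differs in exactly this way, so nothing measured here shows how large a step to expect. The three values shown all lie in a narrow band, and the change is a swap of one ring for another of similar size at the same place. The expectation is therefore for no step beyond the scatter, with the estimated step amounting to a 1.3-fold lower number from compound 2 to compound 4 (0.11 log units; within the scatter). Compound 4 is expected to give about 13000 nM in this assay, most likely between 4500 nM and 38000 nM.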

Compound 4, half-maximal inhibitory concentration: 19000 nM
Compound 4: middle estimate off by 1.5-fold (0.16 log units), on the low side; low and high end bracket the measured number.
By their numbers in this assay, from the lowest: compound 3; then compounds 1, 2 and 4 (each within the scatter of the next).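

In this assay, putting 4-(methylsulfonyl)piperazin-1-yl in place of 3-carbamoylpiperidin-1-yl on a carbonyl carbon gives a 1.1-fold higher number from compound 2 to compound 4 (0.05 log units; within the scatter), so this pair cannot be told apart. Within the data shown here, this is the first direct comparison at this place, and it shows that the read-out does not separate these two groups even though they differ in makeup: the entering group has sulfur, a second hetero atom in the ring and no hydrogen-bond donor, while the leaving group has a carbamoyl group with one such donor. Nothing available here explains why the two compounds read alike.

A single pair of six-membered rings cannot show whether this place responds to other kinds of group, such as a simple open-chain dimethylamino group, a piperidine bearing a carboxylic acid or a piperazine bearing a basic methyl amine. On these data alone, it also remains open whether the same ring swap would read alike in a compound carrying a cyclohexyl group in place of the tert-butyl group of compound 2.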